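This account rests on a few compounds, and the source may have more. Where it says the series, first, only, none or still open, it means among the compounds named here.

Compound 1 `COC(=O)C(Cc1cc(OC)c(OC)c(OC)c1)c1ccc(OC)cc1` and compound 2 `COc1cc(/C=C/c2ccc(C(C)(C)C)cc2)cc(OC)c1OC` were both tested in a functional assay on HT-29 cells (Homo sapiens) for cytotoxicity; a higher number here means that more compound is needed for the effect, a lower number that less compound is needed. In this assay compound 1 gives only a limit, > 25 uM. In this assay compound 2 likewise gives only a limit, > 25 uM, so nothing finer than that is known for it. Both measured values sit at the limit of > 25 uM in this assay, at which 2 of the 2 values shown sit. Compound 3 `COc1cc(/C=C/c2ccc(SC)cc2)cc(OC)c1OC` differs from compound 2 by one change: methylsulfanyl in place of tert-butyl on an aromatic carbon. Among the compounds with values here, no measured pair shows what this change does here. The step is expected to stay within the usual scatter: a number no higher from compound 2 to compound 3 (the limit leaves the size open). Compound 3 is therefore estimated at 25 uM, within 5 uM to 60 uM, and may again appear only as a limit.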

Compound 3, concentration for half-maximal effect: 8.3 uM
Beside the measured number, compound 3's estimate is 3.0-fold (0.48 log units) above it; low and high end bracket the measured number.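

Until now, every compound shown sat at the same limit in this assay, so none gave a number that could be compared. At this position on the aromatic ring, methylsulfanyl in place of tert-butyl gives the first measurable number, with an at least 3.0-fold lower number from compound 2 to compound 3 (0.47 log units; beyond the scatter) as the step. The full size of that step stays unknown, because compound 2 gives only a limit: the limit of > 25 uM in this assay, at which 2 of the 3 values shown sit.

As far as these compounds go, whether the sulfur itself matters remains open, since a single replacement cannot separate it from the loss of tert-butyl. A methoxy group or an amine at this position would help to answer that.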